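The source may hold more compounds than are shown below. What is called first, only, known or untested is meant among the compounds shown, and "the series" means these compounds.

Measured compounds:
compound 1 `CCC(C(=O)N1CCN(c2ccccc2)CC1)N1C(=O)CCC1=O` 75%
compound 2 `CC(C(=O)N1CCN(c2ccc(C(F)(F)F)cc2)CC1)N1C(=O)CCC1=O` 25%
compound 3 `CC(C(=O)N1CCN(c2cccc(F)c2)CC1)N1C(=O)CCC1=O` 100%

In a functional assay on the whole organism (strain Swiss) with Mus musculus as the target, in the maximal electroshock model, with a stated time of 0.25 h, at a dose of 300 mg/kg by the intraperitoneal route (a lower number here means a weaker effect, a higher number a stronger effect of the compound at the dose given), compound 3 gives 100%, the highest of the three numbers. The nearest is compound 1 with 75%, a gap beyond the scatter; the furthest is compound 2 with 25%, also beyond the scatter. Within the data shown here, compound 1 and compound 2 differ from compound 3 in more than one place, so no single-change step between measured compounds is available.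

Compound 4 `CC(C(=O)N1CCN(c2ccccc2)CC1)N1C(=O)CCC1=O` has not been measured. It differs from compound 3 by one change: hydrogen in place of fluoro on an aromatic carbon. The change removes one heavy atom and nothing else; the shared core and the methyl side chain stay as in compound 3.

A lone fluorine is a small edit, and compound 1, which also carries an unsubstituted phenyl ring, gives 75%, so the expectation is a modest downward step from compound 3, the estimated step being a number 25 percentage points lower from compound 3 to compound 4 (beyond the scatter). Compound 4 is therefore expected to give about 75% in this assay, with a range from 50% to 100%.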

Compound 4, a percentage reported as activity, at one dose (the size of the read-out at that dose, not a potency): 100%
Compound 4: the middle estimate sits 25 percentage points below what was measured, within the range that was stated.
By their numbers in this assay, from the lowest: compound 2; then compound 1; then compounds 3 and 4 (each within the scatter of the next).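

In this assay the change from 3-fluorophenyl to phenyl gives no change at the digits printed from compound 3 to compound 4 (within the scatter) and so the fluoro on this aromatic carbon is not needed for the read-out at this dose. Hydrogen in place of trifluoromethyl on an aromatic carbon gives a number 75 percentage points higher from compound 2 to compound 4 (beyond the scatter) and so the ring does not accept every group alike. Hydrogen in place of methyl on a saturated chain carbon gives a number 25 percentage points higher from compound 1 to compound 4 (beyond the scatter) as a modest step, which marks the side chain as a second point where a single change moves the read-out.

No data bearing on the reasons for these steps are at hand. Open too, on these data alone, is how a chloro or methoxy group on the aromatic carbon, or a propyl chain on the saturated chain carbon, would read, and whether compound 3 and compound 4 would still match at lower doses.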